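Acetamido on the saturated ring: from compound 2 to compound 4

This account rests on a few compounds, and the source may have more. Where it says the series, first, only, none or still open, it means among the compounds named here.

Measured so far:
- compound 1, `c1ccc2sc(Oc3ccc4oc(CN5CCCCC5)cc4c3)nc2c1`: "not determined" (no result reported)
- compound 2, `c1ccc2sc(Oc3ccc4c(CN5CCCCC5)coc4c3)nc2c1`: 420 nM
- compound 3, `c1cnc2nc(Oc3ccc4oc(CN5CCCCC5)cc4c3)sc2c1`: 91 nM

All three share a core, and the read-out is an assay on isolated protein (blood, strain CD1) for inhibition of leukotriene A-4 hydrolase (Mus musculus), read by immunoassay, with stated times of 15 min and 30 min; a higher number here means a weaker inhibitor, a lower number a stronger inhibitor. Compound 1 was entered in this assay without a result. Of the two numbers available, compound 2 gives the higher one; compound 3 gives a lower number, and the gap between the two lies beyond the usual scatter. Among the measured compounds shown here, compound 2 and compound 3 differ in more than one place, so no single step joins them.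

The new compound is compound 4, `CC(=O)NC1CCN(Cc2coc3cc(Oc4nc5ccccc5s4)ccc23)CC1`. It differs from compound 2 in one place: acetamido in place of hydrogen on a saturated ring carbon, so that piperidin-1-yl becomes 4-acetamidopiperidin-1-yl. For the measured compounds named here, no measured pair shows this change, so its effect is unknown. The expectation is a step of small size, if any, with the number for compound 4 staying close to that of compound 2, a 1.4-fold lower number from compound 2 to compound 4 (0.15 log units; within the scatter). Compound 4 is therefore estimated at 300 nM, in a range from 90 nM to 1000 nM.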

Compound 4, half-maximal inhibitory concentration: 100 nM
Compound 4: the middle estimate sits 3.0-fold (0.48 log units) above what was measured, within the range that was stated.
By their numbers in this assay, from the lowest: compounds 3 and 4 (each within the scatter of the next); then compound 2.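

Among the compounds shown here, this is the first view of what the saturated ring tolerates. In this assay, acetamido on a saturated ring carbon, three ring bonds from the ring nitrogen, gives a 4.2-fold lower number from compound 2 to compound 4 (0.62 log units; beyond the scatter), a modest step beyond the scatter, so this ring carbon can carry a group larger than hydrogen with a gain rather than a loss in inhibition. No measurement shown here explains why the number falls.

From the compounds shown here alone, it remains open whether the gain belongs to acetamido in particular or would also come with a plain amine, a carboxylic acid or a longer chain on the same ring carbon. Also open, going by these compounds, is whether acetamido would give a similar step on compound 3, whose core differs from that of compound 2.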